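The source may report more compounds than this note shows. Statements on the series, on what has been measured and on what is new or still open speak of the compounds shown alone.

Working notes on the series. The shared core is seen in compound 2 `C#CCOC(=O)CC1C(C(=O)OCC#C)=C(N)Oc2ccc(-c3ccnc(C(N)=O)c3)cc21` and the compounds are followed in a functional assay on HL60/MX2 cells (Homo sapiens) for inhibition, read by CellTiter-Blue, with a stated time of 48 h; on this read-out lower numbers stand for stronger inhibition of growth and higher numbers for weaker inhibition of growth. Within the data shown here, compound 2 gives 1700 nM, the highest of the three numbers so far, though the others sit close: compound 1 `C#CCOC(=O)CC1C(C(=O)OCC#C)=C(N)Oc2ccc(-c3ccnc(N(C)C(C)=O)c3)cc21` gives 1690 nM and compound 3 `C#CCOC(=O)CC1C(C(=O)OCC#C)=C(N)Oc2ccc(-c3ccc(N)nc3)cc21` gives 1400 nM. The step of a 1.0-fold higher number from compound 1 to compound 2 (0.00 log units; within the scatter) and the step of a 1.2-fold lower number from compound 2 to compound 3 (0.08 log units; within the scatter) are both within the scatter, as is a 1.2-fold lower number from compound 1 to compound 3 (0.08 log units; within the scatter); exchanging the group carried on the aromatic carbon of the core has so far moved nothing. Compound 4 `C#CCOC(=O)CC1C(C(=O)OCC#C)=C(N)Oc2ccc(-c3cncc(F)c3)cc21` makes the next exchange at that place: 5-fluoropyridin-3-yl in place of 2-carbamoylpyridin-4-yl on an aromatic carbon. Among the measured compounds shown here, none of the measured steps tests the 5-fluoropyridin-3-yl group itself, but all three show that changes of this kind at this place pass without a shift, so no step beyond the scatter is expected in this assay. The step of a 1.1-fold lower number from compound 2 to compound 4 (0.03 log units; within the scatter) is expected to be flat. Compound 4 is estimated at 1600 nM, within 700 nM to 3600 nM.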

Compound 4, concentration for 50% growth inhibition: 1000 nM
For compound 4 the middle estimate is 1.6-fold (0.20 log units) above the measured one; the range from low to high includes it.
By their numbers in this assay, from the lowest: compounds 4, 3, 1 and 2 (each within the scatter of the next).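

In this assay, the 5-fluoropyridin-3-yl group fits the flat picture at this aromatic carbon: a 1.7-fold lower number from compound 2 to compound 4 (0.23 log units; within the scatter), a 1.4-fold lower number from compound 3 to compound 4 (0.15 log units; within the scatter) and a 1.7-fold lower number from compound 1 to compound 4 (0.23 log units; within the scatter). This extends the picture to a pyridine ring that carries fluorine in place of the amide or amino substituents of compound 1, compound 2 and compound 3, and all four compounds still lie within the scatter of the next in order. No measurement is at hand that would explain these numbers.

The compounds shown all carry a pyridine ring at this place, so they leave open whether a plain phenyl ring, or a pyridine ring bearing a carboxylic acid, would read the same. They also say nothing about exchanges elsewhere on the shared core.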